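Swapping a Halogen for an Ester on the Urea Aryl

This account rests on a few compounds, and the source may have more. Where it says the series, first, only, none or still open, it means among the compounds named here.

Two ureas built on the same core have been measured. Compound 1 `COc1ccc(NC(=O)NCC2(c3ccccc3)CCCCC2)cc1` gives 4900 nM in an assay on microsomes from intestine for inhibition of acyl-CoA:cholesterol acyltransferase (Oryctolagus cuniculus) (a higher number here means a weaker inhibitor, a lower number a stronger inhibitor), and compound 2 `O=C(NCC1(c2ccccc2)CCCCC1)Nc1ccc(I)cc1` gives 2300 nM, the lowest of the two numbers, with a 2.1-fold lower number from compound 1 to compound 2 (0.33 log units; beyond the scatter). Compound 3 `CCOC(=O)c1ccc(NC(=O)NCC2(c3ccccc3)CCCCC2)cc1` differs from compound 2 in one place: ethoxycarbonyl in place of iodo on an aromatic carbon. Among the compounds with values here, only that single step at the same position bears on this change, and it was modest, so no large movement is expected in this assay. Compound 3 is estimated at 3500 nM, between 1200 nM and 10000 nM, which as a step means a 1.5-fold higher number from compound 2 to compound 3 (0.18 log units; within the scatter), expected to stay near the scatter.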

Compound 3, half-maximal inhibitory concentration: 6100 nM
Beside the measured number, compound 3's estimate is 1.7-fold (0.24 log units) below it, and the stated range covers the measured number.
By their numbers in this assay, from the lowest: compound 2; then compounds 1 and 3 (each within the scatter of the next).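

Iodo is the better of these two groups at this aromatic carbon in this assay, and ethoxycarbonyl gives up the small gain seen there (a 2.7-fold higher number from compound 2 to compound 3 (0.42 log units; beyond the scatter)). Ethoxycarbonyl and methoxy cannot be told apart (a 1.2-fold higher number from compound 1 to compound 3 (0.10 log units; within the scatter)), so among these three groups only iodo stands out. Nothing measured here explains why iodo gives the lowest number. As far as these compounds go, whether bromo or chloro would match iodo remains open. So does whether a carboxylic acid or an amine on this carbon would give a number lower than that of compound 2.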